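Nitro substitution on the benzamide ring of compound 3

The source may report more compounds than this note shows. Statements on the series, on what has been measured and on what is new or still open speak of the compounds shown alone.

For the measured compounds named here, compound 3 `CCCCCCCCCCCCn1nnc(C(NC(=O)c2ccccc2)c2ccccc2)n1` carries the lowest of the two numbers measured so far: in an assay on microsomes from liver for inhibition of sterol O-acyltransferase 1 (Rattus norvegicus) (a higher number here means a weaker inhibitor, a lower number a stronger inhibitor), compound 3 gives 350 nM. Compound 2 `CCCCCCCCCCCCn1nnc(C(NC(=O)c2ccc(F)cc2F)c2ccccc2)n1` gives 490 nM, and the step of a 1.4-fold lower number from compound 2 to compound 3 (0.15 log units; within the scatter) lies within the scatter. For compound 1 `CCCCCCCCCCC(C)(C)NC(=O)c1c(OC)cc(OC)cc1OC` this assay reports only a limit, > 10000 nM.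

Compound 4 `CCCCCCCCCCCCn1nnc(C(NC(=O)c2cccc([N+](=O)[O-])c2)c2ccccc2)n1` differs from compound 3 by nitro in place of hydrogen on an aromatic carbon. Going by the values given here, the one measured step that touches the same ring, a 1.4-fold lower number from compound 2 to compound 3 (0.15 log units; within the scatter), stayed within the scatter, so for compound 4 a step in this assay no larger than the scatter is expected, with no direction favoured. Compound 4 is therefore estimated at 400 nM in this assay, between 150 nM and 1200 nM. That estimate amounts to an expected 1.1-fold higher number from compound 3 to compound 4 (0.06 log units; within the scatter).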

Compound 4, half-maximal inhibitory concentration: 80 nM
The estimate for compound 4 lay 5.0-fold (0.70 log units) above the measured number; measured number outside the range, below it.
By their numbers in this assay, from the lowest: compound 4; then compounds 3 and 2 (each within the scatter of the next). At a limit, above all of these: compound 1.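

In this assay, the benzoyl ring responds to substitution at this aromatic carbon: nitro in place of hydrogen gives a 4.4-fold lower number from compound 3 to compound 4 (0.64 log units; beyond the scatter), whereas the earlier change on this ring stayed within the scatter. Replacing 2,4-difluorophenyl with 3-nitrophenyl gives a 6.1-fold lower number from compound 2 to compound 4 (0.79 log units; beyond the scatter). Nothing measured here bears on the reason for the lower number.

Still open, as far as these compounds go, is whether the lower number belongs to nitro itself or would also follow from another group at this place. An amine or a carboxylic acid on the same carbon would separate these two readings.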